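A Nitro Group Tested in the Paw Edema Series

The compounds below may be only part of what the source reports. "The series", "measured", "known", "first", "only" and "open" are said of these compounds alone.

The shared core is an oxime ether acid carrying a six-membered aromatic ring of carbon only. Compound 1 `C/C(=N\OCC(=O)O)c1ccc(C)cc1` bears a methyl on that ring, and in a functional assay on the whole organism for inhibition, with Rattus norvegicus as the target, read by paw edema, with stated times of 1 h and 3 h, at a dose of 50 mg/kg by the oral route (on this read-out lower numbers stand for less inhibition and higher numbers for more inhibition at the one dose given (going by the name of the read-out)), compound 1 gives 20%. Compound 2 `C/C(=N\OCC(=O)O)c1ccc(C(C)(C)C)cc1` carries a tert-butyl in place of the methyl. In this assay compound 2 gives only a limit of the assay, < 20%. Compound 3 `C/C(=N\OCC(=O)O)c1ccc(N(C)C)cc1` carries a dimethylamino instead. In this assay compound 3 likewise gives a limit, < 20%. Compound 2 thus stands at the floor of the reported numbers, sharing it with compound 3 (the limit of < 20% in this assay, at which 2 of the 3 values shown sit).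

The measured steps leave little to read: a number no higher from compound 1 to compound 2 (the limit leaves the size open); a number no higher from compound 1 to compound 3 (the limit leaves the size open); and a step that the two limits leave unreadable from compound 2 to compound 3. None of them fixes a size.

Compound 4 `C/C(=N\OCC(=O)O)c1ccc([N+](=O)[O-])cc1` follows from compound 2 by the change (nitro in place of tert-butyl on an aromatic carbon). The two steps from compound 1 both reach the limit without a readable size, and the step between compound 2 and compound 3 is unreadable, so no direction beyond the scatter can be drawn from them. The step is therefore expected to be a step that the limit leaves unreadable from compound 2 to compound 4, that is, none beyond the scatter. In this assay compound 4 is estimated at 15%, expected between 5% and 30%.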

Compound 4, a percentage reported as inhibition, in the whole organism at one dose (the size of the read-out at that dose, not a potency): < 20%
Compound 4: only a limit was reported; the forecaster's own chance of this, stated with the estimate: 60%; the middle value does not contradict the limit.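

In this assay compound 4 gives < 20% as a limit of the assay. Nitro, made of nitrogen and oxygen and carrying hydrogen-bond acceptors, therefore ends at the same limit as tert-butyl, made of carbon only and carrying none, so this change of atoms at the position para to a group of 8 heavy atoms yields no readable number: the limit of < 20% in this assay, at which 3 of the 4 values shown sit. Replacing methyl with nitro gives a number no higher from compound 1 to compound 4 (the limit leaves the size open) and so fixes no size, while the steps among the compounds at the limit cannot be read; compound 1, with methyl, is the one compound shown that goes against this shared limit.

From the compounds shown here alone, whether a primary amine, a carboxylic acid or a longer chain at this position would give a readable number in this assay stays open. Going by these compounds, it also stays open how far compound 2, compound 3 and compound 4 lie under their shared limit, and whether they differ from one another at all.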